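The compounds below may be only part of what the source reports. "The series", "measured", "known", "first", "only" and "open" are said of these compounds alone.

Compound 3 `COc1ccc2nc(C)cc(OCC(=O)Nc3cc(C)ccc3C)c2c1` was tested in a toxicity assay on HepG2 cells (Homo sapiens) for inhibition, read by CellTiter-Glo, with a stated time of 48 h; on this read-out higher numbers stand for weaker inhibition and lower numbers for stronger inhibition. Here compound 3 gives only a limit of the assay, > 100000 nM, and not a number. Compound 1 `Cc1cc(C)cc(NC(=O)COc2cc(C)nc3ccccc23)c1` likewise returns a limit, > 100000 nM. For the measured compounds named here, compound 2 `Cc1cc(C)cc(NC(=O)COc2cc(C)nc3ccc(C)cc23)c1` is the one compound with a measured number, 15900 nM, and the step of an at least 6.2-fold lower number from compound 1 to compound 2 (0.79 log units; beyond the scatter) is the only measured step in the set. Compound 4 `COc1ccc2nc(C)cc(OCC(=O)Nc3c(C)cncc3C)c2c1` differs from compound 3 in one place: 3,5-dimethylpyridin-4-yl in place of 2,5-dimethylphenyl on an amide-type nitrogen. Going by the values given here, no measured step involves such a change, so nothing here sets its size or direction, and because two of the three values sit at the limit of > 100000 nM in this assay, at which 2 of the 3 values shown sit, compound 4 is expected to stay near that limit. The estimate for compound 4 is 100000 nM, ranging from 30000 nM to 300000 nM, an expected step of a number no higher from compound 3 to compound 4 (the limit leaves the size open).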

Compound 4, half-maximal inhibitory concentration: 12600 nM
Estimate against measurement, compound 4: 7.9-fold (0.90 log units) above; measured number outside the range, below it.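

In this assay, 3,5-dimethylpyridin-4-yl in place of 2,5-dimethylphenyl on the amide-type nitrogen gives an at least 7.9-fold lower number from compound 3 to compound 4 (0.89 log units; beyond the scatter). So this group, and not only the methyl on the core that separates compound 1 from compound 2, affects the read-out, although the swap alters both the ring atoms and the arrangement of the methyl groups, and these effects cannot be separated here. The full size of the step stays unknown, because compound 3 stands at a limit: the limit of > 100000 nM in this assay, at which 2 of the 4 values shown sit.

From the compounds shown here alone, whether an amine or a carboxylic acid on this ring would move the number further remains open. So does whether the same swap would act alike on the core of compound 1.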